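A few compounds are considered here, and "the series" means these few. Any claim that something is new, unique, unknown or untested is made for them only; others in the source may bear on it.

The measured compounds:

compound 1, `Clc1ccc(-c2n[nH]c3c2CCNCC3)cc1`, gives in an assay on cells for displacement of a labelled ligand from 5-hydroxytryptamine receptor 3A (Homo sapiens), read by scintillation counting, with a stated time of 1.5 h (on this read-out lower numbers stand for stronger inhibition and higher numbers for weaker inhibition), only a limit, > 10000 nM.
compound 2, `Cc1ccc(-c2noc3c2CCNCC3)cc1`, gives in this assay a value of 420 nM.
compound 3, `Clc1ccc(-c2noc3c2CCNCC3)cc1`, gives in this assay a value of 303 nM.

Compound 1 thus stands at the edge of what this assay can report, as a limit rather than a number (the limit of > 10000 nM in this assay, at which 1 of the 3 values shown sits). Compound 4, `Cc1ccc(-c2n[nH]c3c2CCNCC3)cc1`, has not yet been measured; it differs from compound 1 by methyl in place of chloro on an aromatic carbon. Among the compounds with values here, the one measured step of the same kind runs on the core of compound 2: a 1.4-fold lower number from compound 2 to compound 3 (0.14 log units; within the scatter). Read in the opposite direction, methyl in place of chloro there moved the number only within the scatter, so no step beyond the scatter is expected for compound 4, which would leave it at the limit. Compound 4 is therefore expected to give 15000 nM, with a range from 5000 nM to 50000 nM, the expected step being a step that the limit leaves unreadable from compound 1 to compound 4.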

Compound 4, inhibition constant: > 10000 nM
Compound 4 was reported as a limit; the forecaster's own chance of this, stated with the estimate: 75%; the middle value does not contradict the limit.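

In this assay, within the data shown here, compound 1 and compound 4 are both reported only as limits, so no step between them can be read: the limit of > 10000 nM in this assay, at which 2 of the 4 values shown sit.

On these data alone, what methyl in place of chloro does to the number on the core of compound 1 stays open.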